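Swapping isopropyl for hydroxymethyl: what to expect of compound 3

The source may hold more compounds than are shown below. What is called first, only, known or untested is meant among the compounds shown, and "the series" means these compounds.

Compound 1 `CC(S)C(=O)N[C@@H](C)C(=O)O`: 18300000 nM
Compound 2 `CC(S)C(=O)N[C@H](C(=O)O)C(C)C`: 12800000 nM

Both values come from a functional assay on KB 3-1 cells (Homo sapiens) for cytotoxicity, read by MTT assay, with a stated time of 72 h; a higher number here means a weaker inhibitor, a lower number a stronger inhibitor. Within the data shown here, compound 2 lies within the scatter of compound 1, the only other measured compound, so the two are best read as one level.

Compound 3 `CC(S)C(=O)N[C@@H](CO)C(=O)O` has not yet been measured. Its difference from compound 2 is hydroxymethyl in place of isopropyl on a saturated chain carbon bound to an amide-type nitrogen and a carbonyl carbon.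

Among the measured compounds shown here, one measured step bears on this change, since it was made on the same saturated chain carbon: a 1.4-fold lower number from compound 1 to compound 2 (0.16 log units; within the scatter). Going from methyl to isopropyl there left the number within the scatter. For the measured compounds named here, no measured compound carries hydroxymethyl, so this evidence is indirect and the range must stay wide. No step beyond the scatter is expected in this assay, and no direction can be favoured with confidence.

For compound 3 the expected value is 15000000 nM, with an estimated range of 7000000 nM to 32000000 nM. This estimate amounts to an expected 1.2-fold higher number from compound 2 to compound 3 (0.07 log units; within the scatter).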

Compound 3, half-maximal inhibitory concentration: 17900000 nM
Estimate against measurement, compound 3: 1.2-fold (0.08 log units) below; low and high end bracket the measured number.
By their numbers in this assay, from the lowest: compounds 2, 3 and 1 (each within the scatter of the next).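

Hydroxymethyl is the first group at this saturated chain carbon to carry a hydrogen-bond donor and a hydrogen-bond acceptor, and isopropyl has neither, yet in this assay this exchange gives a 1.4-fold higher number from compound 2 to compound 3 (0.15 log units; within the scatter). Read against the smallest group shown, hydroxy in place of hydrogen on a saturated chain carbon, two bonds along the chain from an amide-type nitrogen and a carbonyl carbon, gives a 1.0-fold lower number from compound 1 to compound 3 (0.01 log units; within the scatter), so methyl, isopropyl and hydroxymethyl now all sit at one level and the earlier flat step no longer stands alone. Across these three groups, then, neither the exchange of carbon for oxygen nor the added donor and acceptor separates the compounds in this cell test, and no supporting measurement is available to explain why.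

Going by these compounds, whether this position stays as flat for a group of a different kind, such as an amine or a longer chain, remains open. The compounds shown also share the rest of the core, so they leave open whether the same level would hold if the thiol were replaced by a hydroxy group or an amine.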